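The compounds below may be only part of what the source reports. "The series", "measured", "known", "first", "only" and "open" are said of these compounds alone.

Measured compounds:
compound 1, `Cc1cccc(-c2csc(N)c2C(=O)OCc2ccccc2)c1`, 68%
compound 2, `COc1cccc(-c2csc(N)c2C(=O)OCc2ccccc2)c1`, 57%

In an assay on isolated protein for inhibition of protein kinase C zeta type (Homo sapiens), with stated times of 1 h and 2.5 min, tested at 30 uM (a lower number here means less inhibition, a higher number more inhibition at the concentration tested (going by the name of the read-out)), compound 1 gives 68%, and compound 2 gives 57%. Compound 2 thus holds the lower of the two numbers; its nearest neighbour is compound 1, and the step of a number 11 percentage points lower from compound 1 to compound 2 (beyond the scatter) lies beyond the scatter. Compound 3, `COc1ccc(-c2csc(N)c2C(=O)OCc2ccccc2)cc1`, is not yet measured. It differs from compound 2 by 4-methoxyphenyl in place of 3-methoxyphenyl on an aromatic carbon. For the measured compounds named here, the only measured step, a number 11 percentage points lower from compound 1 to compound 2 (beyond the scatter), exchanges a methyl for a methoxy and so does not test an exchange of 3-methoxyphenyl for 4-methoxyphenyl; it shows only that this part of the molecule can move the number by a modest amount. With nothing bearing directly on the change, a step within the scatter in either direction is expected in this assay. For compound 3 an inhibition of 55% is therefore expected, with a range from 35% to 75%. This corresponds to an expected step of a number 2 percentage points lower from compound 2 to compound 3 (within the scatter).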

Compound 3, a percentage reported as inhibition, at one concentration (the size of the read-out at that concentration, not a potency): 86%
Estimate against measurement, compound 3: 31 percentage points below, outside the stated range (above it).
By their numbers in this assay, from the lowest: compound 2; then compound 1; then compound 3.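

In this assay, the exchange of 3-methoxyphenyl for 4-methoxyphenyl gives a number 29 percentage points higher from compound 2 to compound 3 (beyond the scatter), so with the same atoms joined differently, the placement of the methoxy group on the phenyl ring moves the number, which the earlier exchange of methyl for methoxy could not show. The exchange of 3-methylphenyl for 4-methoxyphenyl gives a number 18 percentage points higher from compound 1 to compound 3 (beyond the scatter), so a methoxy-bearing ring at this position does not always give the lower number: the earlier drop belongs to the 3-methoxyphenyl compound alone. Nothing available explains why the placement matters.

On these data alone, whether an amine or a carboxylic acid in place of that methoxy group would keep the number this high remains open. These percentages, each taken at one concentration, also leave the potency of the compounds unknown.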